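Adding an isopropyl at the imidazole-side chain of compound 3

The source may report more compounds than this note shows. Statements on the series, on what has been measured and on what is new or still open speak of the compounds shown alone.

Of the compounds shown here, three have been measured in a functional assay on L1210 cells (Mus musculus) for antiproliferative activity; on this read-out lower numbers stand for lower potency and higher numbers for higher potency (the scale is a negative logarithm). Compound 1, `CN(C)/N=N/c1cccc(C(N)=O)c1`, gives 3.8. Compound 2, `CN(C)/N=N/c1nc(Cc2ccccc2)[nH]c1C(N)=O`, gives 2.89. Compound 3, `Cc1nc(/N=N/N(C)C)c(C(N)=O)[nH]1`, gives 3.06. Compound 3 thus stands second of the three: its nearest neighbour is compound 2, and their gap lies within the scatter, while compound 1 sits above it by a gap beyond the scatter.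

Among the compounds with values here, the only single-point step measured so far is a number 0.17 log units higher from compound 2 to compound 3 (within the scatter), a change that sits at the same place as the one now in question, on a saturated chain carbon bound to an aromatic carbon. Swapping phenyl for hydrogen there moved this assay hardly at all.

Compound 4, `CC(C)Cc1nc(/N=N/N(C)C)c(C(N)=O)[nH]1`, differs from compound 3 by isopropyl in place of hydrogen on a saturated chain carbon bound to an aromatic carbon. Since the earlier change at this same carbon, from phenyl to hydrogen, left this assay essentially unchanged, the reverse sort of move, hydrogen to isopropyl, is expected to do the same: the step is estimated at a number 0.06 log units lower from compound 3 to compound 4 (within the scatter), with no direction that can be trusted beyond the scatter. Compound 4 is therefore expected to give about 3 in this assay, with a likely range from 2.5 to 3.5.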

Compound 4, logarithm of the reciprocal of the active concentration, log(1/C): 3.53
Beside the measured number, compound 4's estimate is 0.53 log units below it; the measured number lies above the stated range.
By their numbers in this assay, from the lowest: compounds 2 and 3 (each within the scatter of the next); then compounds 4 and 1 (each within the scatter of the next).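

Isopropyl in place of hydrogen on a saturated chain carbon bound to an aromatic carbon gives, in this assay, a number 0.47 log units higher from compound 3 to compound 4 (beyond the scatter), so the read-out can respond to a change at this place, which the earlier step had not shown. Isopropyl in place of phenyl gives a number 0.64 log units higher from compound 2 to compound 4 (beyond the scatter), whereas the earlier step, a number 0.17 log units higher from compound 2 to compound 3 (within the scatter), lies within the scatter: phenyl and hydrogen cannot be told apart here, yet isopropyl stands apart from both, so what counts is which group enters, not merely whether a group is present. The data shown offer nothing that explains this difference.

From the compounds shown here alone, with only hydrogen, phenyl and isopropyl at this carbon, it remains open whether a longer chain, a cyclohexyl ring or a chain ending in an amine would keep, extend or lose the rise. Going by these compounds, it also remains open whether the same change would give a similar step on a different core, such as that of compound 1.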